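Replacing the trifluoromethylphenyl group: a step toward compound 4

The source may hold more compounds than are shown below. What is called first, only, known or untested is meant among the compounds shown, and "the series" means these compounds.

The three measured compounds share one core and differ only in the aryl group on the fused ring system. Compound 1 `CCCS(=O)(=O)Nc1ccc(F)c(C(=O)c2n[nH]c3ncc(-c4ccccc4Cl)cc23)c1F` gives 9.3% in an assay for binding affinity to dual specificity mitogen-activated protein kinase kinase 4 (Homo sapiens), read by KINOMEscan, tested at 100 nM; a lower number here means a stronger effect, a higher number a weaker effect of the compound at the concentration tested. Compound 2 `CCCS(=O)(=O)Nc1ccc(F)c(C(=O)c2n[nH]c3ncc(-c4ccc(N)cc4)cc23)c1F` gives 0.1% in this assay. Compound 3 `CCCS(=O)(=O)Nc1ccc(F)c(C(=O)c2n[nH]c3ncc(-c4ccc(C(F)(F)F)cc4)cc23)c1F` gives 29% in this assay, the highest of the three numbers, with a number 19.7 percentage points higher from compound 1 to compound 3 (beyond the scatter) and a number 28.9 percentage points higher from compound 2 to compound 3 (beyond the scatter) both beyond the scatter, while a number 9.2 percentage points lower from compound 1 to compound 2 (within the scatter) lies within it.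

Compound 4 `CCCS(=O)(=O)Nc1ccc(F)c(C(=O)c2n[nH]c3ncc(-c4cccc([N+](=O)[O-])c4)cc23)c1F` is the next step from compound 3: 3-nitrophenyl in place of 4-(trifluoromethyl)phenyl on an aromatic carbon. Both measured steps that end at compound 3 bear on this change, since each swaps one aryl group for another at the same place and each raised the number by a modest amount. Within the data shown here, a move away from the 4-(trifluoromethyl)phenyl group is therefore expected to lower the number in this assay, though the 3-nitrophenyl group has no direct precedent here, so the size is uncertain. Compound 4 is expected to give 12% in this assay, within a range from 1% to 35%, which means an expected step of a number 17 percentage points lower from compound 3 to compound 4 (beyond the scatter).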

Compound 4, a percentage reported as activity, at one concentration (the size of the read-out at that concentration, not a potency): 15%
Beside the measured number, compound 4's estimate is 3 percentage points below it; the range from low to high includes it.
By their numbers in this assay, from the lowest: compounds 2, 1 and 4 (each within the scatter of the next, the first and the last beyond it); then compound 3.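

Within this assay, the 3-nitrophenyl group does not share the weaker reading of the 4-(trifluoromethyl)phenyl group, with a number 14 percentage points lower from compound 3 to compound 4 (beyond the scatter), so an electron count aside, a phenyl ring with a non-amino substituent at this place need not read as high as compound 3 does. The step of a number 5.7 percentage points higher from compound 1 to compound 4 (within the scatter) leaves the 3-nitrophenyl and 2-chlorophenyl groups unseparated, while a number 14.9 percentage points higher from compound 2 to compound 4 (beyond the scatter) keeps the 4-aminophenyl group apart from the 3-nitrophenyl group. No measurement given here accounts for these differences.

Compound 4 differs from compound 3 both in the group on the phenyl ring and in where that group stands, so these compounds cannot separate the two. As far as these compounds go, what a phenyl ring carrying a carboxylic acid or a nitrile would give at this place remains open.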